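Solubility of Compound 1 and Its Acetyl Analogue

A few compounds are considered here, and "the series" means these few. Any claim that something is new, unique, unknown or untested is made for them only; others in the source may bear on it.

- In a physicochemical assay for solubility, at pH 7.4 (on this read-out higher numbers stand for higher solubility and lower numbers for lower solubility), compound 1 `C=CC(=O)Nc1cccc(-n2c(-c3nc(-c4cnn(C5CCN(C)CC5)c4)cnc3N)nc3ccccc32)c1` gives < 10000 nM, a limit.
- In this assay, compound 2 `C=CC(=O)Nc1cccc(-n2c(-c3nc(-c4cnn(C5CCN(C)CC5)c4)cnc3N)nc3ccccc32)c1F` gives < 10000 nM, a limit.
- In this assay, compound 3 `C=CC(=O)Nc1ccccc1Cn1c(-c2nc(-c3cnn(C4CCN(C)CC4)c3)cnc2N)nc2ccccc21` gives 35000 nM.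

Compound 1 has no exact number and stands only at a limit, (the limit of < 10000 nM in this assay, at which 2 of the 3 values shown sit). Compound 4 `C=CC(=O)Nc1cccc(-n2c(-c3nc(-c4cnn(C5CCN(C(C)=O)CC5)c4)cnc3N)nc3ccccc32)c1` differs from it by one change, acetyl in place of methyl on an amine nitrogen in a ring. The measured steps all lie elsewhere on the molecule. These are an at least 3.5-fold higher number from compound 1 to compound 3 (0.54 log units; beyond the scatter), an at least 3.5-fold higher number from compound 2 to compound 3 (0.54 log units; beyond the scatter) and a step that the two limits leave unreadable from compound 1 to compound 2. None of them alters the 1-methylpiperidin-4-yl group, so they give no size for this change. Only a small step to a lower number is therefore expected in this assay, namely a step that the limit leaves unreadable from compound 1 to compound 4. Compound 4 is estimated at 5000 nM, with an expected range from 1500 nM to 15000 nM.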

Compound 4, solubility: < 10000 nM
Compound 4: a limit, no number (the forecaster's own chance of this, stated with the estimate: 65%); the middle value lies beyond the limit too.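

No step can be read from compound 1 to compound 4, since both stand only at a limit in this assay: the limit of < 10000 nM in this assay, at which 3 of the 4 values shown sit.

The compounds shown leave open how far 1-acetylpiperidin-4-yl in place of 1-methylpiperidin-4-yl shifts the number in this assay.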